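Swapping a carbamate for a pyrimidine amide on the piperidine

This account rests on a few compounds, and the source may have more. Where it says the series, first, only, none or still open, it means among the compounds named here.

Compound 2 `CCC1(OC(=O)N2CCC(Oc3ncnc(Oc4ccc(S(C)(=O)=O)nc4C)c3F)CC2)CC1` is the reference point here. Among the compounds with values here, in a functional assay on isolated protein for inhibition of Glucose-dependent insulinotropic receptor (Rattus norvegicus), read by HTRF and cAMP accumulation (a lower number here means that less compound is needed, a higher number that more compound is needed for the effect), compound 2 gives 333 nM, the lowest of the three numbers measured so far. Compound 1 `Cc1nc(S(C)(=O)=O)ccc1Oc1ncnc(OC2CCN(C(=O)O[C@H](C)CF)CC2)c1F` gives 1520 nM, and compound 3 `Cc1nc(S(C)(=O)=O)ccc1Oc1ncnc(OC2CCN(C(=S)OC(C)C)CC2)c1F` gives 1050 nM. The steps from these two neighbours both change the group on the amine nitrogen in the ring: a 4.6-fold lower number from compound 1 to compound 2 (0.66 log units; beyond the scatter), and a 3.2-fold higher number from compound 2 to compound 3 (0.50 log units; beyond the scatter). Between compound 1 and compound 3 the step is a 1.4-fold lower number from compound 1 to compound 3 (0.16 log units; within the scatter).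

Compound 4 `CCc1cnc(C(=O)N2CCC(Oc3ncnc(Oc4ccc(S(C)(=O)=O)nc4C)c3F)CC2)nc1` changes the same end of the molecule again, this time on the carbonyl carbon: a group of 8 heavy atoms (6 carbon, 2 nitrogen; one six-membered aromatic ring with 2 hetero atoms) in place of a group of 6 heavy atoms (5 carbon, 1 oxygen; one three-membered non-aromatic ring of carbon only), on a carbonyl carbon. The measured steps show that replacing the 1-ethylcyclopropyl group by other groups at this position cost a modest amount each time, so a modest move toward a higher number is expected here as well, a 2.3-fold higher number from compound 2 to compound 4 (0.35 log units; beyond the scatter). Compound 4 is thus estimated at 750 nM, with a likely range from 250 nM to 2200 nM.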

Compound 4, half-maximal effective concentration: 40.8 nM
Beside the measured number, compound 4's estimate is 18-fold (1.26 log units) above it; measured number below the stated range.
By their numbers in this assay, from the lowest: compound 4; then compound 2; then compounds 3 and 1 (each within the scatter of the next).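

Each earlier change to the group on the amine nitrogen in the ring gave a higher number than the 1-ethylcyclopropyl carbamate, but the amide bearing 5-ethylpyrimidin-2-yl goes the other way in this assay (an 8.2-fold lower number from compound 2 to compound 4 (0.91 log units; beyond the scatter)). The gaps to the other two carbamate-type compounds are larger (a 26-fold lower number from compound 3 to compound 4 (1.41 log units; beyond the scatter); a 37-fold lower number from compound 1 to compound 4 (1.57 log units; beyond the scatter)), so an aromatic ring on this carbonyl carbon, with no oxygen linking the two, is not only accepted but gives the lowest number of the four. Nothing available here explains this drop.

From the compounds shown here alone, it remains open whether the pyrimidine ring or its ethyl group accounts for the drop. A plain phenyl ring, or a pyrimidin-2-yl ring carrying a longer chain in place of the ethyl, would help separate the two.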